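Moving the fluorine from compound 2 to compound 3

The source may hold more compounds than are shown below. What is called first, only, known or untested is meant among the compounds shown, and "the series" means these compounds.

In a functional assay on SEM cells (Homo sapiens) for cytotoxicity, with a stated time of 72 h (a lower number here means that less compound is needed, a higher number that more compound is needed for the effect), compound 1 (`C=C[C@@](C)(/C=C/c1ccc(Nc2ccc(OC)cc2)cc1)CCC=C(C)C`) gives > 36600 nM, a limit of the assay. Compound 2 (`C=C[C@@](C)(/C=C/c1ccc(-c2ccc(F)cc2)cc1)CCC=C(C)C`) gives > 36600 nM, also a limit and no number, so it has no measured position in the series. Going by the values given here, the only measured step, a step that the two limits leave unreadable from compound 1 to compound 2, has no readable size, and both compounds share one limit (the limit of > 36600 nM in this assay, at which 2 of the 2 values shown sit). Compound 3 (`C=C[C@@](C)(/C=C/c1ccc(-c2cccc(F)c2)cc1)CCC=C(C)C`) carries a single change: 3-fluorophenyl in place of 4-fluorophenyl on an aromatic carbon. Among the compounds with values here, no step of measurable size bears on this change, so no direction is expected. The estimated step is a step that the limit leaves unreadable from compound 2 to compound 3. For compound 3 the expected value is 40000 nM, with an estimated range of 18000 nM to 80000 nM.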

Compound 3, half-maximal effective concentration: > 36600 nM
Compound 3: only a limit was reported (the forecaster's own chance of this, stated with the estimate: 80%); the middle value is on the limit's open side.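

Going by these compounds alone, no step among compound 1, compound 2 and compound 3 can be read, as all three give a limit and not a number: the limit of > 36600 nM in this assay, at which 3 of the 3 values shown sit. The compounds shown leave open whether 3-fluorophenyl and 4-fluorophenyl differ at all in this assay.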